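The compounds below may be only part of what the source reports. "The series", "measured", "known", "first", "only" and "open" are said of these compounds alone.

Two pairs of compounds here share one structural change. Compound 1 `COc1cc(OC)c(/C=C/S(=O)(=O)Cc2ccc(F)c(N)c2)c(OC)c1` and compound 2 `COc1cc(OC)c(/C=C/S(=O)(=O)Cc2ccc(Cl)c(N)c2)c(OC)c1` differ in a single atom on one aromatic ring, described as chloro in place of fluoro on an aromatic carbon. In a functional assay on K562 cells (Homo sapiens) for cytotoxicity, read by trypan blue exclusion, with a stated time of 96 h (a lower number here means a stronger inhibitor, a higher number a weaker inhibitor), compound 1 gives 2500 nM, while compound 2 gives 10 nM, so that the step of a 250-fold lower number from compound 1 to compound 2 (2.40 log units; beyond the scatter) is very large and well beyond the scatter of this assay.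

Compound 3 `COC(=O)C(Nc1cc(CS(=O)(=O)/C=C/c2c(OC)cc(OC)cc2OC)ccc1OC)c1ccc(F)cc1` is built on a different core, and the difference between the two cores is not broken down here. In this assay compound 3 gives 800 nM, a number higher than that of compound 1 and far higher than that of compound 2. Compound 4 `COC(=O)C(Nc1cc(CS(=O)(=O)/C=C/c2c(OC)cc(OC)cc2OC)ccc1OC)c1ccc(Cl)cc1` is related to compound 3 by chloro in place of fluoro on an aromatic carbon. For the measured compounds named here, this is the same kind of change as the one from compound 1 to compound 2, but not the same: in the first pair the place is ortho to an amino group and para to a large group, whereas in the second pair it is only para to a large group, on a separate phenyl ring.

Because the earlier step of a 250-fold lower number from compound 1 to compound 2 (2.40 log units; beyond the scatter) was made at a place with different surroundings, the step from compound 3 to compound 4 is expected to be smaller, with an estimated 3.2-fold lower number from compound 3 to compound 4 (0.51 log units; beyond the scatter). Compound 4 is expected to give 250 nM, estimated between 50 nM and 1500 nM.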

Compound 4, half-maximal inhibitory concentration: 200 nM
Compound 4: middle estimate off by 1.3-fold (0.10 log units), on the high side; the measured number falls inside the stated range.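

In this assay, chloro in place of fluoro gives a 4.0-fold lower number from compound 3 to compound 4 (0.60 log units; beyond the scatter), so the number falls on this core as well, just as it fell on the core of compound 1. The direction of the change therefore carries over between the two cores, but its size does not: the same change on two cores in this assay, a 250-fold lower number (2.40 log units; beyond the scatter) from compound 1 to compound 2 and a 4.0-fold lower number (0.60 log units; beyond the scatter) from compound 3 to compound 4, 63-fold (1.80 log units) apart, beyond the scatter of two such steps

For the compounds shown here, these two pairs do not show whether the smaller step belongs to the core itself or to the different surroundings of the changed carbon, since the pairs differ in both at once, and with only two examples they give no rule for what the same change would do on a third core.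

The compounds shown leave open how other groups would behave at the same place, such as a bromo group, a methyl group or plain hydrogen on the ring that carries the chloro in compound 4, and whether the order of fluoro and chloro would hold for them on both cores. They also leave open whether a carboxylic acid in place of the methoxycarbonyl group would change the number in compound 4 or alter the size of the step from fluoro to chloro.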